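Thiosemicarbazone series: furan to pyrrole swap on the hydrazone

The compounds below may be only part of what the source reports. "The series", "measured", "known", "first", "only" and "open" are said of these compounds alone.

Measured compounds:
- compound 1 `CC1=CC[C@H](C(C)(C)NC(=S)NN)CC1` — 200 nM
- compound 2 `CC1=CC[C@H](C(C)(C)NC(=S)N/N=C/c2ccc(O)cc2)CC1` — > 100000 nM, a limit of the assay
- compound 3 `CC1=CC[C@H](C(C)(C)NC(=S)N/N=C/c2ccco2)CC1` — 9700 nM
- compound 4 `CC1=CC[C@H](C(C)(C)NC(=S)N/N=C/c2ccc[nH]2)CC1` — not yet measured

In a functional assay on U-251 cells (Homo sapiens) for inhibition, read by sulforhodamine B assay, with a stated time of 48 h (a lower number here means a stronger inhibitor of growth, a higher number a weaker inhibitor of growth), compound 3 carries the highest of the two numbers obtained so far; its nearest neighbour is compound 1, separated by a 49-fold higher number from compound 1 to compound 3 (1.69 log units; beyond the scatter). Compound 2 stands only at the limit of this assay (the limit of > 100000 nM in this assay, at which 1 of the 3 values shown sits). From that limit to compound 3 the step is an at least 10-fold lower number from compound 2 to compound 3 (1.01 log units; beyond the scatter). The step to compound 4 is 1H-pyrrol-2-yl in place of furan-2-yl on a carbon with a double bond to nitrogen. Neither measured step exchanges one five-membered ring for another: one removes the whole hydrazone substituent, the other replaces 4-hydroxyphenyl with furan-2-yl, and both are large. For the measured compounds named here, a ring of the same size with only its hetero atom changed gives no comparable precedent for a large shift, so in this assay the step of a 1.0-fold higher number from compound 3 to compound 4 (0.01 log units; within the scatter) is expected, within the scatter. Compound 4 is therefore estimated at 10000 nM, with a range from 3000 nM to 40000 nM.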

Compound 4, concentration for 50% growth inhibition: 80 nM
For compound 4 the middle estimate is 130-fold (2.10 log units) above the measured one; the whole stated range lies above it.
By their numbers in this assay, from the lowest: compound 4; then compound 1; then compound 3. At a limit, above all of these: compound 2.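

In this assay, the place on a carbon with a double bond to nitrogen proves sensitive to the hetero atom alone: with ring size unchanged, 1H-pyrrol-2-yl in place of furan-2-yl gives a 120-fold lower number from compound 3 to compound 4 (2.08 log units; beyond the scatter). For the compounds shown here, the hydrazone substituent is also not detrimental in itself, as the earlier steps might have suggested, since the comparison with compound 1, which lacks that substituent, shows a 2.5-fold lower number from compound 1 to compound 4 (0.40 log units; beyond the scatter). The step of an at least 1200-fold lower number from compound 2 to compound 4 (3.09 log units; beyond the scatter) starts from a limit, that of compound 2: the limit of > 100000 nM in this assay, at which 1 of the 4 values shown sits.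

The compounds shown do not separate the gain of the ring hydrogen-bond donor from the loss of the furan oxygen as the feature that matters. A 1-methylpyrrol-2-yl or thiophen-2-yl group at the same place would bear on that question.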